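Cyclohexyl for Trimethoxyphenyl on the Amine of Compound 1

The source may report more compounds than this note shows. Statements on the series, on what has been measured and on what is new or still open speak of the compounds shown alone.

The measured compounds:
Compound 1, `COc1ccc(Cn2nc(-c3ccccc3)c3cc(C(=N)Nc4cccc(C(F)(F)F)c4)nc(Nc4cc(OC)c(OC)c(OC)c4)c32)cc1`: in a functional assay on MDA-MB-231 cells (Homo sapiens) for cytotoxicity, read by MTT assay, with a stated time of 72 h (a lower number here means a stronger inhibitor, a higher number a weaker inhibitor), compound 1 gives > 50000 nM, which is a limit of the assay rather than a number.
Compound 2, `CN1CCN(c2ccc(NC(=N)c3cc4c(-c5ccccc5)nn(C)c4cn3)cc2)CC1`: compound 2 gives 4900 nM.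
Compound 3, `COc1cc(Nc2nc(C(=N)Nc3cccc(C(F)(F)F)c3)cc3c(-c4ccccc4)n[nH]c23)cc(OC)c1OC`: compound 3 gives 7600 nM.

Compound 1 therefore stands only as a limit, the weakest reading that this assay can report, as shown by the limit of > 50000 nM in this assay, at which 1 of the 3 values shown sits. Compound 4, `COc1ccc(Cn2nc(-c3ccccc3)c3cc(C(=N)Nc4cccc(C(F)(F)F)c4)nc(NC4CCCCC4)c32)cc1`, has not yet been measured. It differs from compound 1 in a single place: cyclohexyl in place of 3,4,5-trimethoxyphenyl on a nitrogen on an aromatic ring.

Within the data shown here, only one measured step exists, an at least 6.5-fold lower number from compound 1 to compound 3 (0.81 log units; beyond the scatter), and it concerns a different place on the shared core, the aromatic nitrogen that carries hydrogen in place of 4-methoxybenzyl. Among the measured compounds shown here, no measured pair changes the group on the nitrogen whose other neighbour is aromatic carbon, so no step bears on the change from compound 1 to compound 4. Compound 2 and compound 3 give numbers, but neither pairs with compound 4 by a single change.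

For the measured compounds named here, with compound 1 at a limit and no guiding step, the expected step is estimated as an at least 1.2-fold lower number from compound 1 to compound 4 (0.09 log units; that floor lies within the scatter), and its direction remains uncertain. Compound 4 is expected to give 40000 nM, within 8000 nM to 100000 nM, with a considerable chance that only a limit is reported again.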

Compound 4, half-maximal inhibitory concentration: > 50000 nM
Compound 4 was reported as a limit; the forecaster's own chance of this, stated with the estimate: 50%; at least 1.2-fold (0.09 log units) between middle value and limit.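

In this assay compound 4 gives > 50000 nM, which is a limit and not a number. Compound 1 stands at a limit as well, so the step from compound 1 to compound 4 cannot be read: the limit of > 50000 nM in this assay, at which 2 of the 4 values shown sit.

The compounds shown leave open whether cyclohexyl and 3,4,5-trimethoxyphenyl on a nitrogen on an aromatic ring differ in strength at all, and if so, which gives the stronger inhibitor.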